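The source may hold more compounds than are shown below. What is called first, only, known or untested is meant among the compounds shown, and "the series" means these compounds.

Measured compounds:
Compound 1, `Cc1cc(Nc2cc(-c3ccccc3)[nH]n2)n2nc(SCc3csc4ccccc34)nc2n1`: in a functional assay on PC-9 cells (Homo sapiens) for inhibition, read by MTT assay, with a stated time of 72 h (on this read-out higher numbers stand for weaker inhibition and lower numbers for stronger inhibition), compound 1 gives 4420 nM.
Compound 2, `Cc1cc(Nc2cc(-c3ccccc3)[nH]n2)n2nc(SCc3nc4ccccc4[nH]3)nc2n1`: compound 2 gives 4840 nM.
Compound 3, `Cc1cc(Nc2cc(-c3ccccc3)[nH]n2)n2nc(SCc3ccccc3Br)nc2n1`: compound 3 gives 5630 nM.

Compound 3 holds the highest number of the three, yet its gaps to the others, a 1.2-fold higher number from compound 2 to compound 3 (0.07 log units; within the scatter) and a 1.3-fold higher number from compound 1 to compound 3 (0.11 log units; within the scatter), are both within the scatter, so the three stand level. Compound 4, `Cc1cc(Nc2cc(-c3ccccc3)[nH]n2)n2nc(SCc3cccc4ccccc34)nc2n1`, carries the change (naphthalen-1-yl in place of 2-bromophenyl on a saturated chain carbon bound to a sulfur). Among the measured compounds shown here, the steps that bear on it all swap the group on the saturated chain carbon bound to a sulfur: a 1.1-fold higher number from compound 1 to compound 2 (0.04 log units; within the scatter), a 1.3-fold higher number from compound 1 to compound 3 (0.11 log units; within the scatter) and a 1.2-fold higher number from compound 2 to compound 3 (0.07 log units; within the scatter), each within the scatter. Compound 1 carries 1-benzothiophen-3-yl at that place and stands level with compound 3. Compound 4 is therefore expected to show a 1.2-fold lower number from compound 3 to compound 4 (0.07 log units; within the scatter), nothing beyond the scatter. The estimate for compound 4 is 4800 nM, with a range from 2200 nM to 10500 nM.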

Compound 4, half-maximal inhibitory concentration: 3950 nM
Estimate against measurement, compound 4: 1.2-fold (0.08 log units) above; the measured number falls inside the stated range.
By their numbers in this assay, from the lowest: compounds 4, 1, 2 and 3 (each within the scatter of the next).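

In this assay naphthalen-1-yl, with its 2 six-membered aromatic rings of carbon only, leaves the number within the scatter of all three earlier groups on the saturated chain carbon bound to a sulfur (a 1.4-fold lower number from compound 3 to compound 4 (0.15 log units; within the scatter)) (a 1.2-fold lower number from compound 2 to compound 4 (0.09 log units; within the scatter)) (a 1.1-fold lower number from compound 1 to compound 4 (0.05 log units; within the scatter)). This place therefore accepts a group made of carbon alone as well as the groups carrying bromine, sulfur or nitrogen, with no step beyond the scatter among these four compounds. No evidence bears on why these groups stand level.

Going by these compounds, whether an amine, a carboxylic acid or a longer chain at this place would shift the number beyond the scatter remains open.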